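A 3-phenylprop-2-en-1-yl Analogue of Compound 1

A few compounds are considered here, and "the series" means these few. Any claim that something is new, unique, unknown or untested is made for them only; others in the source may bear on it.

Compound 1 `O=C1N(Cc2cccc(Cl)c2)c2cccn2S(=O)(=O)N1Cc1ccccc1` was tested in an ADME assay on MT4 cells (Homo sapiens) for cytotoxicity, read by MTT assay, with a stated time of 5 days (a lower number here means that less compound is tolerated, a higher number that more compound is tolerated), where compound 1 gives 196000 nM. Its closest neighbour is compound 2 `O=C1N(Cc2cccc(Cl)c2)c2cccn2S(=O)(=O)N1Cc1cccc(F)c1`, which in this assay gives 208000 nM. For the measured compounds named here, the only single-point step among the measured compounds is a 1.1-fold higher number from compound 1 to compound 2 (0.03 log units; within the scatter), so compound 1 and compound 2 sit within the scatter of each other. Compound 3 `O=C1N(Cc2ccc(Cl)cc2Cl)c2cccn2S(=O)(=O)N1Cc1cccc(Br)c1` reaches only a limit of this assay, > 243000 nM, and gives no number. Thus compound 1 has one of only two numbers shown, and the other is indistinguishable from it.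

Compound 4 `O=C1N(C/C=C/c2ccccc2)c2cccn2S(=O)(=O)N1Cc1ccccc1` differs from compound 1 in one place: 2-phenylethenyl in place of 3-chlorophenyl on a saturated chain carbon bound to an amide-type nitrogen in a ring. Going by the values given here, no measured step involves this change; the one measured step, the fluoro substitution, stayed within the scatter, and the limit of > 243000 nM in this assay, at which 1 of the 3 values shown sits, shows that a further analogue is tolerated to the top of the range. The step of a 1.0-fold higher number from compound 1 to compound 4 (0.01 log units; within the scatter) is therefore expected to stay within the scatter. Compound 4 is estimated at 200000 nM, within 100000 nM to 300000 nM.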

Compound 4, half-maximal cytotoxic concentration: > 318000 nM
Compound 4: only a limit was reported; the forecaster's own chance of this, stated with the estimate: 30%; middle value at least 1.5-fold (0.20 log units) away from the limit.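

In this assay, compound 4 gives only a limit and not a number: the limit of > 318000 nM in this assay, at which 1 of the 4 values shown sits.

Unlike the fluoro step, which concerned an aromatic carbon, this change lies on a saturated chain carbon bound to an amide-type nitrogen in a ring, and it gives the first reading at that place: an at least 1.6-fold higher number from compound 1 to compound 4 (0.21 log units; that floor lies within the scatter). As far as these compounds go, the true size of the step stays unknown and its floor cannot be told from the scatter, but the result does show that 2-phenylethenyl, which carries no chlorine and has a double bond outside aromatic rings, can stand in place of 3-chlorophenyl without any drop in the tolerated concentration.

The compounds shown leave open how far this place accepts other groups, such as an amine, a carboxylic acid or a saturated 3-phenylpropyl chain. They also leave open whether the double bond itself matters to the result.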